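The compounds below may be only part of what the source reports. "The series", "measured", "known", "first", "only" and "open" are said of these compounds alone.

Of the compounds shown here, three sharing one core have been measured in a functional assay on HeLa cells (Homo sapiens) for cytotoxicity, read by WST assay, with a stated time of 48 h; on this read-out higher numbers stand for weaker inhibition and lower numbers for stronger inhibition. Compound 1 `CCCCCC/C=C/C[C@H]1C[C@@H]([C@@H](O)c2ccccc2)CO[C@@H]1c1ccccc1`, with hexyl on the double-bonded chain, gives 7400 nM. Compound 2 `Oc1ccccc1/C=C/C[C@H]1C[C@@H]([C@@H](O)c2ccccc2)CO[C@@H]1c1ccccc1`, with 2-hydroxyphenyl at that place, gives 21800 nM. Compound 3 `COc1ccccc1/C=C/C[C@H]1C[C@@H]([C@@H](O)c2ccccc2)CO[C@@H]1c1ccccc1`, with 2-methoxyphenyl there, gives 14700 nM.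

The number for compound 3 lies between the other two, and neither of its steps leaves the usual scatter: the first is a 2.0-fold higher number from compound 1 to compound 3 (0.30 log units; within the scatter), and the second is a 1.5-fold lower number from compound 2 to compound 3 (0.17 log units; within the scatter). For the measured compounds named here, only the step of a 2.9-fold higher number from compound 1 to compound 2 (0.47 log units; beyond the scatter) goes beyond the scatter, and it is modest.

Compound 4 `O[C@@H](c1ccccc1)[C@H]1CO[C@H](c2ccccc2)[C@@H](C/C=C/c2ccc(F)cc2)C1` keeps the core and changes in one place: 4-fluorophenyl in place of 2-methoxyphenyl on a double-bonded chain carbon bound to a double-bonded chain carbon. Put simply, 4-fluorophenyl stands in place of 2-methoxyphenyl on a double-bonded chain carbon bound to a double-bonded chain carbon. Going by the values given here, no measured compound carries 4-fluorophenyl, so the evidence is indirect. The two compounds with an aromatic ring at this place differ little, as the step of a 1.5-fold lower number from compound 2 to compound 3 (0.17 log units; within the scatter) shows, and so only a small change is expected here. The expected step is a 1.2-fold lower number from compound 3 to compound 4 (0.09 log units; within the scatter), which would not go beyond the scatter. Compound 4 is estimated at 12000 nM, with an expected range from 5500 nM to 26000 nM.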

Compound 4, half-maximal inhibitory concentration: 8340 nM
The estimate for compound 4 lay 1.4-fold (0.16 log units) above the measured number; the range from low to high includes it.
By their numbers in this assay, from the lowest: compounds 1, 4, 3 and 2 (each within the scatter of the next, the first and the last beyond it).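

In (this assay), an aromatic ring at this place need not give a different number from a plain chain: 4-fluorophenyl, which has no hydrogen-bond donors or acceptors, stands level with hexyl, with (a 1.1-fold higher number from compound 1 to compound 4 (0.05 log units; within the scatter)). The change from 2-methoxyphenyl to 4-fluorophenyl stays small, with (a 1.8-fold lower number from compound 3 to compound 4 (0.25 log units; within the scatter)), while the change from 2-hydroxyphenyl to 4-fluorophenyl gives (a 2.6-fold lower number from compound 2 to compound 4 (0.42 log units; beyond the scatter)), the first sign that two aromatic rings at this place can differ beyond the scatter. Nothing available here accounts for these differences.

The compounds shown carry hexyl or a phenyl ring with one added group at this place, and the added groups differ both in kind and in where they sit on the ring, so those two changes cannot be told apart. Open questions are how unsubstituted phenyl, 4-hydroxyphenyl or 4-methoxyphenyl would compare with these compounds, and whether a shorter chain such as butyl or a chain ending in an amine would stay level with hexyl.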